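This account rests on a few compounds, and the source may have more. Where it says the series, first, only, none or still open, it means among the compounds named here.

Measured so far in an assay (strain Wistar) for displacement of a labelled ligand from adenosine receptor A1 (Rattus norvegicus), read by scintillation counting; a lower number here means a stronger inhibitor, a higher number a weaker inhibitor: compound 1 `COc1ccc(Cl)cc1C(=O)Nc1nc(-c2ccccc2)nc2c1nnn2Cc1ccccc1` gives 7150 nM; compound 2 `Cc1ccc(C(=O)Nc2nc(-c3ccccc3)nc3c2nnn3Cc2ccccc2)cc1` gives 709 nM; compound 3 `O=C(Nc1nc(-c2ccccc2)nc2c1nnn2Cc1ccccc1)c1ccc(C(F)(F)F)cc1` gives 123 nM.

Compound 3 stands at the lowest number of the three, and both gaps are beyond the scatter: a 5.8-fold lower number from compound 2 to compound 3 (0.76 log units; beyond the scatter) and a 58-fold lower number from compound 1 to compound 3 (1.76 log units; beyond the scatter). The unmeasured compound 4 `O=C(Nc1nc(-c2ccccc2)nc2c1nnn2Cc1ccccc1)c1ccccc1F` differs from compound 3 in one place: 2-fluorophenyl in place of 4-(trifluoromethyl)phenyl on a carbonyl carbon. All three measured steps also change this aromatic ring on the carbonyl carbon, so all of them bear on the new step. The step of a 5.8-fold lower number from compound 2 to compound 3 (0.76 log units; beyond the scatter) shows that swapping methyl for trifluoromethyl on that ring lowered the number by a modest amount; compound 4 loses the trifluoromethyl altogether, so the number is expected to rise. Within the data shown here, the only measured compound with a ring substituted away from the 4-position, compound 1 with its 5-chloro-2-methoxyphenyl, gives by far the highest number, as a 58-fold lower number from compound 1 to compound 3 (1.76 log units; beyond the scatter) shows, though that ring also carries a chlorine and a methoxy, so it is not a clean guide for a single fluorine. Among the measured compounds shown here, no measured compound carries a lone fluorine on this ring. Compound 4 is therefore expected to be weaker than compound 3 by a modest step, an 8.1-fold higher number from compound 3 to compound 4 (0.91 log units; beyond the scatter), landing near compound 2. The estimate for compound 4 in this assay is 1000 nM, with a range from 250 nM to 4000 nM.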

Compound 4, inhibition constant: 40 nM
Compound 4: middle estimate off by 25-fold (1.40 log units), on the high side; the whole stated range lies above it.
By their numbers in this assay, from the lowest: compound 4; then compound 3; then compound 2; then compound 1.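

Changing the ring on the carbonyl carbon to 2-fluorophenyl gives the strongest inhibitor of the four in this assay (a 3.1-fold lower number from compound 3 to compound 4 (0.49 log units; beyond the scatter)), so a low number here does not depend on trifluoromethyl. The same ring also clearly beats 4-methylphenyl (an 18-fold lower number from compound 2 to compound 4 (1.25 log units; beyond the scatter)), which shows that a 4-substituted ring is not required and that a single fluorine can outperform both 4-substituted groups. The widest gap in the set (a 180-fold lower number from compound 1 to compound 4 (2.25 log units; beyond the scatter)) separates two rings whose names both carry a group at the 2 position, so that position alone does not produce a high number, and the chlorine, the methoxy or their combination in compound 1 may matter more.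

The compounds shown cannot separate the effect of fluorine from the effect of where it sits, which plain phenyl, 4-fluorophenyl and 2-chlorophenyl would help to settle, and the effect of an amine or a carboxylic acid on this ring also remains open. No available evidence explains why compound 4 gives the lowest number of the four.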